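Cyclopropyl to Isopropoxy on a Shared Fused Core

The source may hold more compounds than are shown below. What is called first, only, known or untested is meant among the compounds shown, and "the series" means these compounds.

Compound 1, `CS(=O)(=O)c1nn2cc(-c3cc4ccccc4o3)nc2s1`: in an assay for antagonist activity at proteinase-activated receptor 4 (Homo sapiens), with stated times of 5 min, 50 s and 15 min, in the presence of a further agent that is not named here (on this read-out lower numbers stand for stronger inhibition and higher numbers for weaker inhibition), compound 1 gives > 30000 nM, a limit of the assay.
Compound 2, `Cc1nn2cc(-c3cc4ccccc4o3)nc2s1`: in this assay compound 2 gives > 30000 nM, a limit of the assay.
Compound 3, `c1ccc2oc(-c3cn4nc(C5CC5)sc4n3)cc2c1`: in this assay compound 3 gives > 30000 nM, a limit of the assay.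

The three measured compounds share one core and differ only in the group on a single aromatic carbon. The steps among them, a step that the two limits leave unreadable from compound 1 to compound 2, a step that the two limits leave unreadable from compound 1 to compound 3 and a step that the two limits leave unreadable from compound 2 to compound 3, cannot be read, since each end sits at a limit. Compound 3 therefore stands at the assay limit, the same place where every measured value sits (the limit of > 30000 nM in this assay, at which 3 of the 3 values shown sit).

Compound 4, `CC(C)Oc1nn2cc(-c3cc4ccccc4o3)nc2s1`, differs from compound 3 in one place: isopropoxy in place of cyclopropyl on an aromatic carbon. Among the measured compounds shown here, no measured step has a readable size, so none points in any direction for this change. What the data do show is that three different groups at this position all left the compounds at the limit (the limit of > 30000 nM in this assay, at which 3 of the 3 values shown sit). On that basis the step in this assay from compound 3 to compound 4 is expected to be a number no higher from compound 3 to compound 4 (the limit leaves the size open), that is, nothing readable beyond the scatter. Compound 4 is accordingly estimated at 30000 nM, with a range from 10000 nM to 100000 nM, and most likely reported again only as a limit.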

Compound 4, half-maximal inhibitory concentration: > 30000 nM
Compound 4 was reported as a limit; the forecaster's own chance of this, stated with the estimate: 80%; the middle value lies on the limit itself.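

In this assay compound 4 gives > 30000 nM, which is again a limit of the assay. The steps to compound 4 from compound 1, compound 2 and compound 3 therefore cannot be read, because each one joins two limits: the limit of > 30000 nM in this assay, at which 4 of the 4 values shown sit. The compounds shown leave open how strongly any of them inhibits the receptor, and whether any group at this position gives a readable value.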